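The source may report more compounds than this note shows. Statements on the series, on what has been measured and on what is new or still open speak of the compounds shown alone.

Compound 1 `COc1cc(OC)c(C(=O)/C=C/c2ccc(O)cc2)c(O)c1C` and compound 2 `COc1cc(O)c(C/C=C(\C)CCC=C(C)C)c(O)c1C(=O)/C=C/c1ccc(O)cc1` were both examined in a functional assay on HeLa cells (Homo sapiens) for cytotoxicity, read by MTT assay, with a stated time of 72 h; a higher number here means a weaker inhibitor, a lower number a stronger inhibitor. In this assay compound 1 gives 12200 nM, the higher of the two numbers, while compound 2 gives 8200 nM; the gap between them falls within the usual scatter of repeated measurements of this kind, so no order between the two can be drawn. Compound 3 `COc1cc(O)c(C(=O)/C=C/c2ccc(O)cc2)c(OC)c1` has not yet been measured. It differs from compound 1 in one place: hydrogen in place of methyl on an aromatic carbon. Going by the values given here, no step between measured compounds that share this change is available, so the expectation rests on the modest size of the change itself. The change removes only a methyl and puts hydrogen in its place, so the step of a 1.0-fold lower number from compound 1 to compound 3 (0.01 log units; within the scatter) is expected to be small and to stay within the scatter, in either direction. Compound 3 is accordingly estimated at 12000 nM, with a range from 5500 nM to 26000 nM.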

Compound 3, half-maximal inhibitory concentration: 19200 nM
Compound 3: middle estimate off by 1.6-fold (0.20 log units), on the low side, within the range that was stated.
By their numbers in this assay, from the lowest: compounds 2, 1 and 3 (each within the scatter of the next, the first and the last beyond it).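

In this assay, going by these compounds alone, hydrogen in place of methyl on this aromatic carbon, ortho to a hydroxy group and to a methoxy group, gives a 1.6-fold higher number from compound 1 to compound 3 (0.20 log units; within the scatter), the first reading of this change at this position. On this single pair, the methyl is therefore not shown to matter to the number, and no order can be drawn between the two compounds. No other measurement bears on this step, so the data offer no explanation of it.

The compounds shown leave open what a group other than methyl or hydrogen would do on this carbon, whether an amine, a carboxylic acid or a longer chain. They also leave open whether the same change would stay as small on another core.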